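Methyl added to the sulfonyl aryl ring of compound 3

The source may hold more compounds than are shown below. What is called first, only, known or untested is meant among the compounds shown, and "the series" means these compounds.

Compound 1 `CCCCOc1ccc(S(=O)(=O)N2CCCC[C@H]2CC(=O)N[C@@H]2CCCc3cc(CNC(C)(C)C)ccc32)cc1`: 590 nM in a functional assay for inhibition of B1 bradykinin receptor (Homo sapiens), read by calcium flux; a higher number here means a weaker inhibitor, a lower number a stronger inhibitor
Compound 2 `COc1ccc(S(=O)(=O)N2CCCC[C@H]2CC(=O)N[C@@H]2CCCc3cc(CNC(C)(C)C)ccc32)cc1`: 1400 nM
Compound 3 `CC(C)(C)NCc1ccc2c(c1)CCC[C@H]2NC(=O)C[C@@H]1CCCCN1S(=O)(=O)c1cccc(Cl)c1`: 73 nM

Compound 3 holds the lowest number of the three, shown by an 8.1-fold lower number from compound 1 to compound 3 (0.91 log units; beyond the scatter) and a 19-fold lower number from compound 2 to compound 3 (1.28 log units; beyond the scatter). Compound 4 `Cc1ccc(S(=O)(=O)N2CCCC[C@H]2CC(=O)N[C@@H]2CCCc3cc(CNC(C)(C)C)ccc32)cc1Cl` differs from compound 3 by methyl in place of hydrogen on an aromatic carbon. Among the compounds with values here, no measured step makes this kind of change: the step of a 2.4-fold higher number from compound 1 to compound 2 (0.38 log units; beyond the scatter) and the two above swap the whole aryl group or shorten its alkoxy chain, so they bear on it only loosely, and they show that this ring tolerates various substituents. The step of a 1.2-fold lower number from compound 3 to compound 4 (0.09 log units; within the scatter) in this assay is therefore expected to be small, within or near the scatter. Compound 4 is expected to give 60 nM, with a range from 25 nM to 150 nM.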

Compound 4, half-maximal inhibitory concentration: 22 nM
Estimate against measurement, compound 4: 2.7-fold (0.44 log units) above; the whole stated range lies above it.
By their numbers in this assay, from the lowest: compound 4; then compound 3; then compound 1; then compound 2.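

In this assay the sulfonyl aryl ring proves sensitive to one added carbon: methyl on the aromatic carbon ortho to the chloro group gives a 3.3-fold lower number from compound 3 to compound 4 (0.52 log units; beyond the scatter) and so does more than be tolerated. The 3-chloro-4-methylphenyl group also far outdoes the alkoxy aryl groups, with a 64-fold lower number from compound 2 to compound 4 (1.80 log units; beyond the scatter) and with a 27-fold lower number from compound 1 to compound 4 (1.43 log units; beyond the scatter) on the same core. No measurement shown here accounts for the gain from this methyl.

As far as these compounds go, whether the gain needs a methyl stays open, since ethyl or a second chloro group on this carbon would test that. Also open, from the compounds shown here alone, is whether methyl works without the chloro group, as in a plain 4-methylphenyl.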